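This account rests on a few compounds, and the source may have more. Where it says the series, first, only, none or still open, it means among the compounds named here.

In a functional assay on SW-620 cells (Homo sapiens) for antiproliferative activity, read by sulforhodamine B assay, with a stated time of 48 h (a lower number here means a stronger inhibitor, a higher number a weaker inhibitor), compound 1 (`O=C(CCCCCCN1C(=O)/C(=N\O)c2ccccc21)NO`) gives 640 nM and compound 2 (`O=C(CCCCCCN1C(=O)/C(=N\O)c2cc(Cl)ccc21)NO`) gives 650 nM in the same experiment type, the two lying within the scatter of each other. Compound 3 (`O=C(CCCCCCN1C(=O)/C(=N\O)c2cc([N+](=O)[O-])ccc21)NO`) gives 3390 nM as the highest number of the three and is the weakest of the set so far.

Compound 4 (`Cc1ccc2c(c1)/C(=N/O)C(=O)N2CCCCCCC(=O)NO`) is still unmeasured. The change is methyl in place of nitro on an aromatic carbon.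

For the measured compounds named here, three measured steps bear on it. The chloro exchange stayed within the scatter (a 1.0-fold higher number from compound 1 to compound 2 (0.01 log units; within the scatter)), while both steps to the nitro compound went beyond it (a 5.3-fold higher number from compound 1 to compound 3 (0.72 log units; beyond the scatter); a 5.2-fold higher number from compound 2 to compound 3 (0.72 log units; beyond the scatter)). Going by the values given here, no methyl compound has been measured, so the expectation rests on compound 1 at 640 nM and compound 2 at 650 nM as the compounds without nitro. Removing nitro is therefore expected to give back a modest step toward a lower number.

The expected change in this assay is (a 4.8-fold lower number from compound 3 to compound 4 (0.69 log units; beyond the scatter)) on this reading. For compound 4 the estimate is 700 nM as a middle value, with an expected range from 300 nM to 1600 nM in this series.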

Compound 4, half-maximal inhibitory concentration: 990 nM
Beside the measured number, compound 4's estimate is 1.4-fold (0.15 log units) below it; low and high end bracket the measured number.
By their numbers in this assay, from the lowest: compounds 1, 2 and 4 (each within the scatter of the next); then compound 3.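

In this assay, methyl at this position cannot be told apart from hydrogen (a 1.5-fold higher number from compound 1 to compound 4 (0.19 log units; within the scatter)) or from chloro (a 1.5-fold higher number from compound 2 to compound 4 (0.18 log units; within the scatter)), so the tolerated set now holds three groups rather than two. Nitro is the only one of the four groups that separates, and exchanging it for methyl gives a step of similar order to those from the other two compounds (a 3.4-fold lower number from compound 3 to compound 4 (0.53 log units; beyond the scatter)), leaving compound 3 alone as the weakest of the four. Nothing measured here accounts for why nitro alone departs from the other three groups.

The compounds shown leave open whether an amine, a carboxylic acid or a methoxy group at this position would stay with hydrogen, chloro and methyl or move with nitro. They also leave open whether the same pattern would hold with a longer chain.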